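Ethoxy in place of 1,1-difluoroethyl: working notes

The compounds below may be only part of what the source reports. "The series", "measured", "known", "first", "only" and "open" are said of these compounds alone.

Going by the values given here, in a physicochemical assay for solubility, at pH 6.5 (a lower number here means a less soluble compound, a higher number a more soluble compound), compound 1 (`CCOc1nc2nc(C)cc(Nc3ccc(C(F)(F)F)cc3)n2n1`) gives 19000 nM as one of only two measured values. Compound 2 (`Cc1cc(Nc2ccc(S(F)(F)(F)(F)F)cc2)n2nc(C(C)(F)F)nc2n1`) gives 30000 nM and stands within the scatter of compound 1. Compound 3 (`CCOc1nc2nc(C)cc(Nc3ccc(S(F)(F)(F)(F)F)cc3)n2n1`) is the next case. The structural change from compound 2 is ethoxy in place of 1,1-difluoroethyl on an aromatic carbon with ethoxy in place of 1,1-difluoroethyl on an aromatic carbon. Among the compounds with values here, no measured pair isolates this change, so the expectation rests on little. Compound 1 already carries ethoxy and gives 19000 nM in this assay so a small downward step is expected, with none beyond the scatter. The estimated change is a 1.7-fold lower number from compound 2 to compound 3 (0.22 log units; within the scatter) and remains uncertain. Compound 3 is expected at 18000 nM (estimated range 6000 nM to 45000 nM).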

Compound 3, solubility: 4000 nM
Compound 3: the middle estimate sits 4.5-fold (0.65 log units) above what was measured; the measured number lies below the stated range.
By their numbers in this assay, from the lowest: compound 3; then compounds 1 and 2 (each within the scatter of the next).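

Working notes, result: in this assay the aromatic carbon between two ring nitrogen atoms turns out not to be neutral, since ethoxy in place of 1,1-difluoroethyl gives a 7.5-fold lower number from compound 2 to compound 3 (0.88 log units; beyond the scatter) on a single measured pair. With ethoxy held fixed, the other single change, pentafluorosulfanyl in place of trifluoromethyl on an aromatic carbon, gives a 4.8-fold lower number from compound 1 to compound 3 (0.68 log units; beyond the scatter) and so shows that this second place also moves the read-out. No measurement at hand explains either step.

Going by these compounds, whether the ethoxy change gives a step of similar size with trifluoromethyl in place of pentafluorosulfanyl remains open, as each step rests on one pair. On these data alone, how a methoxy, a longer alkoxy chain or an amine on the same aromatic carbon would read is also open.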